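The source may hold more compounds than are shown below. What is called first, only, known or untested is meant among the compounds shown, and "the series" means these compounds.

Measured compounds:
- compound 1, `CN1CCN(CN2C(=O)CC(C(c3ccccc3)c3ccccc3)C2=O)CC1`: 75.6 mg/kg
- compound 2, `CC(C)C1CC(=O)N(CN2CCN(C3CCCCC3)CC2)C1=O`: 91.8 mg/kg

Both compounds were tested in a functional assay on the whole organism (strain CD1) with Mus musculus as the target (a higher number here means that more compound is needed for the effect, a lower number that less compound is needed), a test on the living animal. In this assay compound 1 gives 75.6 mg/kg, and compound 2 gives 91.8 mg/kg. The two numbers lie within the scatter of repeated measurements of each other, so the data show no real difference between them on this test. The two compounds also differ in more than one place, so nothing can be read from their pair about any single change.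

Compound 3, `CC(C)C1CC(=O)N(CN2CCN(C)CC2)C1=O`, has not yet been measured. It differs from compound 2 in one place: methyl in place of cyclohexyl on an amine nitrogen in a ring. For the measured compounds named here, no measured pair shows this change on its own, so the expected size of the step from compound 2 to compound 3 in this assay rests on no direct precedent. The expectation is a step of a 1.2-fold higher number from compound 2 to compound 3 (0.08 log units; within the scatter), small and not clearly beyond the scatter. For compound 3 the estimated value in this assay is 110 mg/kg, with a range from 55 mg/kg to 220 mg/kg.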

Compound 3, dose for half-maximal effect: 74.9 mg/kg
Estimate against measurement, compound 3: 1.5-fold (0.17 log units) above, and the stated range covers the measured number.
By their numbers in this assay, from the lowest: compounds 3, 1 and 2 (each within the scatter of the next).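

For the compounds shown here, replacing cyclohexyl with methyl on the amine nitrogen in the ring gives a 1.2-fold lower number from compound 2 to compound 3 (0.09 log units; within the scatter) in this assay, the first direct reading of this change at this position. A ring of carbon can thus give way to a single carbon here with no difference that this test can resolve, so for these two groups the dose needed does not depend on which one sits on that nitrogen. Nothing measured here offers an explanation for this flat result, and none can be given from these compounds.

As far as these compounds go, whether the dose would stay just as flat with other groups on this nitrogen, such as a benzyl group, a longer chain or a chain ending in a carboxylic acid, remains open. From the compounds shown here alone, the change has also been read only once, on the core of compound 2, so it is unknown whether the same swap would behave the same way on the core of compound 1.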